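This account rests on a few compounds, and the source may have more. Where it says the series, first, only, none or still open, it means among the compounds named here.

Compound 1 `O[C@H]1CO[C@H](COCc2ccccc2)[C@@H](OCc2ccccc2)[C@@H]1OCc1ccccc1` carries a hydrogen on the saturated ring carbon of its core and, in a functional assay on HL-60 cells (Homo sapiens) for antiproliferative activity, read by MTT assay (a lower number here means a stronger inhibitor, a higher number a weaker inhibitor), compound 1 is reported as "not active" (no number reported), so it stands on no single number; a second compound in the series shares this outcome. Compound 2 `OCCC[C@@H]1O[C@H](COCc2ccccc2)[C@@H](OCc2ccccc2)[C@H](OCc2ccccc2)[C@H]1O` gives 19300 nM in this assay, while compound 3 `O[C@@H]1[C@@H](OCc2ccccc2)[C@H](OCc2ccccc2)[C@@H](COCc2ccccc2)O[C@H]1CC1CC1` is again "not active" (no number reported). Compound 4 `CC(C)C[C@H]1O[C@H](COCc2ccccc2)[C@@H](OCc2ccccc2)[C@H](OCc2ccccc2)[C@H]1O` differs from compound 1 by isobutyl in place of hydrogen on a saturated ring carbon. Within the data shown here, no measured pair records this step, so its size in this assay is unknown; any gain over compound 1 is expected to be small, and a further result without a number remains likely. Compound 4 is therefore estimated at 30000 nM in this assay, within a range from 8000 nM to 120000 nM.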

Compound 4, half-maximal inhibitory concentration: 13900 nM
Compound 4: the middle estimate sits 2.2-fold (0.33 log units) above what was measured; the range from low to high includes it.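

No step can be read between compound 1 and compound 4, as compound 1 carries no number in this assay and stands as a non-numeric result. The compounds shown leave open how much isobutyl in place of hydrogen changes activity, and no evidence bears on a cause for this result.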